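The source may hold more compounds than are shown below. What is called first, only, known or untested is meant among the compounds shown, and "the series" means these compounds.

Compound 1 `C=Cc1nc(C(=O)OCC)cs1`: in a functional assay on HCT-116 cells (Homo sapiens) for cytotoxicity, with a stated time of 3 days (on this read-out higher numbers stand for weaker inhibition and lower numbers for stronger inhibition), compound 1 gives > 40000 nM, which is a limit of the assay and not a number.
Compound 2 `C#Cc1nc(C(=O)OCC)cs1`: in this assay compound 2 gives > 40000 nM, again a limit of the assay rather than a number.
Compound 3 `C=Cc1nc2ccccc2o1`: in this assay compound 3 gives > 40000 nM, once more a limit and not a number.

Compound 4 `C#Cc1nc2ccccc2o1` has not yet been measured. It differs from compound 3 by ethynyl in place of vinyl on an aromatic carbon. The same kind of change separates compound 1 from compound 2, namely (ethynyl in place of vinyl on an aromatic carbon), but the surroundings differ: in compound 1 the five-membered aromatic ring holds one nitrogen and one sulfur, the carbon is next to the ring nitrogen and the ring sulfur and sits two ring bonds from the ring atom that bears a group of five heavy atoms, whereas in compound 3 the ring holds one nitrogen and one oxygen, is part of a fused or bridged system of two rings, and the carbon is next to the ring nitrogen and the ring oxygen. The difference between the two cores is not broken down here.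

The measured step in this assay is a step that the two limits leave unreadable from compound 1 to compound 2. All values shown sit at the limit of > 40000 nM in this assay, at which 3 of the 3 values shown sit, so nothing indicates the direction or size of that step.

On this basis compound 4 is expected to change by a step that the limit leaves unreadable from compound 3 to compound 4, an expectation resting on compound 3 at > 40000 nM and on the unreadable step that the two limits leave unreadable from compound 1 to compound 2. Compound 4 is therefore estimated at 60000 nM, with an expected range from 20000 nM to 200000 nM.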

Compound 4, half-maximal inhibitory concentration: 11600 nM
Beside the measured number, compound 4's estimate is 5.2-fold (0.71 log units) above it, and the stated range ends above it.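

In this assay, ethynyl in place of vinyl on an aromatic carbon gives an at least 3.4-fold lower number from compound 3 to compound 4 (0.53 log units; beyond the scatter), so on the core of compound 3 this change goes with stronger inhibition, and the printed size is only a lower bound. The same change on the core of compound 1 gives a step that cannot be read, because both values in that pair are limits of the assay and not numbers: the limit of > 40000 nM in this assay, at which 3 of the 4 values shown sit. Carrying the change across cores is therefore neither confirmed nor refuted: the result shows that ethynyl can bring a readable value on one core, but it does not show whether compound 2 differs from compound 1 at all, and a single readable pair establishes no pattern for the series.

The compounds shown leave open whether the readable value of compound 4 depends on the ethynyl group itself, for instance whether a longer chain such as propynyl or an amine on the same aromatic carbon would give a readable value as well. They also leave open whether replacing the ethyl ester of compound 2 with a carboxylic acid or an amide would bring that compound into the readable range, where the step from compound 1 could be compared with the one seen here.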